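Swapping Ethoxy for Tetrazolyl on an Orexin Antagonist

The compounds below may be only part of what the source reports. "The series", "measured", "known", "first", "only" and "open" are said of these compounds alone.

Three compounds have so far been measured in a functional assay on cells for antagonist activity at Orexin/Hypocretin receptor type 1 (Homo sapiens), read by FLIPR and calcium flux; on this read-out lower numbers stand for stronger inhibition and higher numbers for weaker inhibition:

Compound 1 `Cc1c(C#N)ccnc1O[C@@H]1CC[C@@H](C)N(C(=O)c2ccccc2C(F)(F)F)C1` gives 4960 nM.
Compound 2 `CC(=O)Nc1cc(C(=O)N2C[C@H](Oc3nccc(C#N)c3C)CC[C@H]2C)c(-c2ccccc2)cn1` gives 71 nM.
Compound 3 `CCOc1ccccc1C(=O)N1C[C@H](Oc2nccc(C#N)c2C)CC[C@H]1C` gives 2100 nM.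

Compound 3 thus holds the second highest of the three numbers: compound 1 sits above it, while compound 2, built on a different aromatic amide, gives a far lower number. Compound 4 `Cc1c(C#N)ccnc1O[C@@H]1CC[C@@H](C)N(C(=O)c2ccccc2-n2ncnn2)C1` differs from compound 3 in one place: 2H-tetrazol-2-yl in place of ethoxy on an aromatic carbon. Among the compounds with values here, the only measured step that touches this position is a 2.4-fold lower number from compound 1 to compound 3 (0.37 log units; beyond the scatter), a modest lowering. Within the data shown here, no measured step involves a tetrazolyl ring, so the direction of the new change rests on weak ground. An aromatic ring ortho to a large group is nonetheless expected to lower the number beyond the scatter, estimated as a 3.0-fold lower number from compound 3 to compound 4 (0.48 log units; beyond the scatter). Compound 4 is therefore expected to give about 700 nM, within a range of 150 nM to 3000 nM.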

Compound 4, half-maximal inhibitory concentration: 4590 nM
The estimate for compound 4 lay 6.6-fold (0.82 log units) below the measured number; measured number above the stated range.
By their numbers in this assay, from the lowest: compound 2; then compound 3; then compounds 4 and 1 (each within the scatter of the next).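

At this position on the aromatic ring, the 2H-tetrazol-2-yl ring does not keep the modest gain seen with ethoxy, giving a 2.2-fold higher number from compound 3 to compound 4 (0.34 log units; beyond the scatter). Set against trifluoromethyl, it gives a 1.1-fold lower number from compound 1 to compound 4 (0.03 log units; within the scatter), so those two groups cannot be told apart here, and ethoxy stays the best of the three at this place, though only modestly. Nothing available explains why these groups differ.

Going by these compounds, whether a longer chain such as propoxy, or an amine, would do better at this position stays open. So does whether these groups would rank the same way on the aromatic amide of compound 2, which gives 71 nM.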